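Mirror Image of the Top Responder Awaits Measurement

The source may hold more compounds than are shown below. What is called first, only, known or untested is meant among the compounds shown, and "the series" means these compounds.

Of the compounds shown here, three have so far been tested in an in vitro functional assay on SH-EP1 cells for agonist activity at Neuronal acetylcholine receptor; alpha4/beta2 (Homo sapiens), read by FLIPR and calcium flux; a higher number here means a larger maximal response, a lower number a smaller maximal response. Compound 1, `CC(C)Oc1cncc(C2=CC3CNCC(C2)C3)c1`, gives 75% there. Compound 2, `Clc1ccc(C2=CC3CNCC(C2)C3)cn1`, reaches 98% in this assay. Compound 3, `C1=C(c2cccnc2)C[C@H]2CNC[C@@H]1C2`, reaches 114% in this assay and stands highest of the three: compound 2 is its nearest neighbour, with a gap that lies beyond the scatter, and compound 1 is furthest from it, again beyond the scatter.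

Compound 4, `C1=C(c2cccnc2)C[C@@H]2CNC[C@H]1C2`, has not yet been measured. It differs from compound 3 only in configuration: the two compounds have the same atoms and bonds and differ only in configuration as drawn: 2 of 2 stereo elements differ (all stereocentres are inverted: mirror images); a stereocentre at a saturated ring carbon is drawn S in compound 3 and R in compound 4; a stereocentre at a saturated ring carbon is drawn R in compound 3 and S in compound 4. No pair among the measured compounds shows what such an inversion does in this assay, so the data give no step to lean on; the account can only reason from the fact that compound 3 already sits at the top of the measured range, leaving more room below than above. The step from compound 3 to compound 4 is expected to be a number 29 percentage points lower from compound 3 to compound 4 (beyond the scatter), downward and probably beyond the scatter, though with wide uncertainty in either direction. Compound 4 is therefore estimated to reach 85% in this assay, within a range from 35% to 120%.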

Compound 4, largest response reached (reported as percent of maximum), in percent of the reference or control that the assay uses: 111%
Beside the measured number, compound 4's estimate is 26 percentage points below it; low and high end bracket the measured number.
By their numbers in this assay, from the lowest: compound 1; then compound 2; then compounds 4 and 3 (each within the scatter of the next).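

In this assay, for the compounds shown here, inverting both stereocentres gives a number 3 percentage points lower from compound 3 to compound 4 (within the scatter) and so provides the first reading of what a change of configuration alone does. Going by these compounds alone, the maximal response does not separate these two mirror images, something the earlier compounds could not show, as no measured pair among them differed in configuration only. The comparison is a clean one, with no change of group to account for, and it rests on a single structural difference: the fact that compounds 3 and 4 differ only in the configuration as drawn.

This result concerns one pair, one aromatic substituent pattern and one read-out of maximal response, so it says nothing about how much compound each mirror image needs to reach that response, nor about activity at any other receptor. Within the data shown here, it also leaves open whether the two mirror images would still match in this assay if the shared core carried a methoxy group, a nitrile or an amine on its aromatic ring, since compound 1 and compound 2 are drawn without configuration and offer no such pair.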